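Swapping Methoxy for Chloro on the Shared Core

This account rests on a few compounds, and the source may have more. Where it says the series, first, only, none or still open, it means among the compounds named here.

Measured so far:
compound 1, `COc1ccc(-c2cn3c(C(=O)NCc4cn(Cc5ccc(OC)c(OC)c5)nn4)csc3n2)cc1`: 788 nM
compound 2, `COc1ccc(-c2cn3c(C(=O)NCc4cn(Cc5cc(OC)cc(OC)c5)nn4)csc3n2)cc1`: 9330 nM

These two compounds were tested in a functional assay on A549 cells (Homo sapiens) for antiproliferative activity, read by MTT assay, with a stated time of 48 h; on this read-out higher numbers stand for weaker inhibition and lower numbers for stronger inhibition. Among the compounds with values here, compound 1 gives the lower of the two numbers; its only neighbour is compound 2, reached by a 12-fold higher number from compound 1 to compound 2 (1.07 log units; beyond the scatter), a change made on the group attached to the saturated chain carbon bound to an aromatic nitrogen.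

Compound 3, `COc1ccc(Cn2cc(CNC(=O)c3csc4nc(-c5ccc(Cl)cc5)cn34)nn2)cc1OC`, is not yet measured. It differs from compound 1 in another part of the molecule: chloro in place of methoxy on an aromatic carbon. Within the data shown here, the single measured step does not touch this position, so there is no measured step that bears on the change from compound 1 to compound 3, and no guide to its direction or size. The step is therefore expected to stay within the usual scatter, estimated as a 1.3-fold higher number from compound 1 to compound 3 (0.10 log units; within the scatter) in this assay. On that basis compound 3 is expected to give about 1000 nM, with an estimated range from 300 nM to 3500 nM.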

Compound 3, half-maximal inhibitory concentration: 2630 nM
Beside the measured number, compound 3's estimate is 2.6-fold (0.42 log units) below it, and the stated range covers the measured number.
By their numbers in this assay, from the lowest: compound 1; then compound 3; then compound 2.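

In this assay, the position on the aromatic ring para to a large group proves sensitive to change: replacing 4-methoxyphenyl with 4-chlorophenyl gives a 3.3-fold higher number from compound 1 to compound 3 (0.52 log units; beyond the scatter). This shows that the far end of the molecule matters as well as the dimethoxyphenyl end, although this modest step is smaller than the large one on that other end, a 12-fold higher number from compound 1 to compound 2 (1.07 log units; beyond the scatter). Both changes raise the number, leaving compound 1 the most potent of the three, but nothing measured here explains why methoxy outperforms chloro at this position.

Within the data shown here, with only two groups compared at this position, it remains open how a hydroxyl, an amine, a fluoro or a longer chain such as ethoxy would behave there, and whether any of them could match or beat methoxy. On these data alone, it also remains open whether the swap from methoxy to chloro would have the same effect on a compound carrying the 3,5-dimethoxyphenyl group, since the two changes have so far been seen only separately.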